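This account rests on a few compounds, and the source may have more. Where it says the series, first, only, none or still open, it means among the compounds named here.

Compound 1 `Cc1cn(C2CC(N=[N+]=[N-])C(COC(=O)CCCC(=O)OC(C)(C)C)O2)c(=O)[nH]c1=O`: in an ADME assay on the whole organism (serum) with Homo sapiens as the target (a lower number here means that the compound disappears faster, a higher number that the compound lasts longer), compound 1 gives 0.55 h.
Compound 2 `Cc1cn(C2CC(N=[N+]=[N-])C(COC(=O)CCCN)O2)c(=O)[nH]c1=O`: compound 2 gives 0.433 h.
Compound 3 `Cc1cn(C2CC(N=[N+]=[N-])C(COC(=O)OCCCO)O2)c(=O)[nH]c1=O`: compound 3 gives 0.167 h.

Compound 3 stands lowest of the three numbers: a 3.3-fold lower number from compound 1 to compound 3 (0.52 log units; beyond the scatter) and a 2.6-fold lower number from compound 2 to compound 3 (0.41 log units; beyond the scatter), both beyond the scatter, while a 1.3-fold lower number from compound 1 to compound 2 (0.10 log units; within the scatter) lies within it. Compound 4 `Cc1cn(C2CC(N=[N+]=[N-])C(COC(=O)NCCCO)O2)c(=O)[nH]c1=O` differs from compound 3 in one place: (3-hydroxypropyl)amino in place of 3-hydroxypropoxy on a carbonyl carbon. Going by the values given here, no measured step makes this same exchange. The two steps that reach compound 3 both alter the group on a carbonyl carbon and both lowered the number, but neither replaces an oxygen there with a nitrogen, so they give no firm direction for this change. Compound 4 is therefore expected to sit near compound 3, with an estimated step of a 2.7-fold higher number from compound 3 to compound 4 (0.43 log units; beyond the scatter) that may stay modest. The estimate for compound 4 is 0.45 h, ranging between 0.15 h and 1.3 h.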

Compound 4, half-life: > 48 h
Compound 4 was reported as a limit (the forecaster's own chance of this, stated with the estimate: 5%); middle value at least 100-fold (2.02 log units) from the limit.
By their numbers in this assay, from the lowest: compound 3; then compounds 2 and 1 (each within the scatter of the next). At a limit, above all of these: compound 4.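

Compound 4 stands at a limit, not a number, in this assay: the limit of > 48 h in this assay, at which 1 of the 4 values shown sits. On this carbonyl carbon, (3-hydroxypropyl)amino in place of 3-hydroxypropoxy gives an at least 280-fold higher number from compound 3 to compound 4 (2.45 log units; beyond the scatter), far larger than any earlier step, and compound 4 also clears the other two compounds, with an at least 110-fold higher number from compound 2 to compound 4 (2.04 log units; beyond the scatter) and an at least 87-fold higher number from compound 1 to compound 4 (1.94 log units; beyond the scatter). The 3-hydroxypropyl chain is common to compound 3 and compound 4, so the oxygen-to-nitrogen exchange on this carbonyl carbon alone separates them.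

Going by these compounds, the true size of these steps stays open, since compound 4 gives only a limit. On these data alone, it is also open whether a longer chain, or a carboxylic acid in place of the hydroxyl, would keep this result.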